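The source may report more compounds than this note shows. Statements on the series, on what has been measured and on what is new or still open speak of the compounds shown alone.

The measured compounds are:

compound 1, `O=c1c(-c2ccc(O)cc2)coc2cc(OCCCBr)ccc12`, with 90.8% in a functional assay on mitochondria (Cricetulus griseus) for inhibition of Monoamine oxidase (Homo sapiens), tested at 3 uM; on this read-out lower numbers stand for a weaker effect and higher numbers for a stronger effect at the one concentration tested;
compound 2, `O=c1c(-c2ccc(O)cc2)coc2cc(OCCC3OCCCO3)ccc12`, with 75.3%;
compound 3, `O=C(O)CCCCCCCCCOc1ccc2c(=O)c(-c3ccc(O)cc3)coc2c1`, with 89.6%.

Compound 3 stands second highest of the three numbers. Its nearest neighbour is compound 1, where the step is a number 1.2 percentage points lower from compound 1 to compound 3 (within the scatter); its furthest is compound 2, where the step is a number 14.3 percentage points higher from compound 2 to compound 3 (beyond the scatter). Compound 4, `CCOc1ccc2c(=O)c(-c3ccc(O)cc3)coc2c1`, has not been measured. It differs from compound 3 by hydrogen in place of 7-carboxyheptyl on a saturated chain carbon, two bonds along the chain from an oxygen on an aromatic ring. Going by the values given here, two steps bear on this, both acting at the same place on the chain: from compound 1 to compound 3 the change was a number 1.2 percentage points lower from compound 1 to compound 3 (within the scatter), and from compound 2 to compound 3 it was a number 14.3 percentage points higher from compound 2 to compound 3 (beyond the scatter). Among the compounds with values here, neither was large, yet the group now removed is the whole chain end, larger than anything exchanged before, and the only exchange that did move the number moved it down. Compound 4 is therefore expected to fall modestly, by about a number 11.6 percentage points lower from compound 3 to compound 4 (beyond the scatter), with wide uncertainty. The estimate for compound 4 is 78%, within a range from 55% to 93%.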

Compound 4, a percentage reported as inhibition, at one concentration (the size of the read-out at that concentration, not a potency): 95.6%
Beside the measured number, compound 4's estimate is 17.6 percentage points below it; measured number outside the range, above it.
By their numbers in this assay, from the lowest: compound 2; then compounds 3, 1 and 4 (each within the scatter of the next).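

Hydrogen in place of 7-carboxyheptyl on this saturated chain carbon leaves the number in this assay within the scatter (a number 6 percentage points higher from compound 3 to compound 4 (within the scatter)), and hydrogen in place of bromomethyl does the same (a number 4.8 percentage points higher from compound 1 to compound 4 (within the scatter)), so at this concentration neither chain end is needed for the effect. Hydrogen in place of the group carrying the six-membered non-aromatic ring in compound 2 is the one exchange here that goes beyond the scatter (a number 20.3 percentage points higher from compound 2 to compound 4 (beyond the scatter)), which sets compound 2 apart from the other three. Nothing measured here accounts for this difference.

The compounds shown leave open whether an amine at the chain end would stay with compounds 1, 3 and 4 or fall with compound 2. As far as these compounds go, with one concentration per compound, their relative potency also remains open.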